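A methyl on the 2-carboxyethyl chain of compound 1

The source may hold more compounds than are shown below. What is called first, only, known or untested is meant among the compounds shown, and "the series" means these compounds.

Compound 1 `Cc1cccc(C)c1-c1cccc(COc2ccc(CCC(=O)O)cn2)c1` gives the lowest of the two numbers recorded in a functional assay on CHO cells for agonist activity at Free fatty acid receptor 1 (Rattus norvegicus), read by calcium flux (on this read-out lower numbers stand for an effect already at smaller amounts and higher numbers for an effect only at larger amounts of compound), namely 38 nM. For the measured compounds named here, its nearest neighbour, compound 2 `Cc1cc(OCc2cccc(-c3c(C)cccc3C)c2)ncc1CCC(=O)O`, gives 130 nM, and the single step of a 3.4-fold higher number from compound 1 to compound 2 (0.53 log units; beyond the scatter) comes from methyl in place of hydrogen on an aromatic carbon. Compound 3 `Cc1cccc(C)c1-c1cccc(COc2ccc(C(C)CC(=O)O)cn2)c1` differs from compound 1 by methyl in place of hydrogen on a saturated chain carbon bound to an aromatic carbon and a saturated chain carbon, which turns 2-carboxyethyl into 1-(carboxymethyl)ethyl. Going by the values given here, the only measured step adds a methyl elsewhere, on an aromatic carbon, and it raised the number modestly; no measured pair probes a methyl on the chain itself, so the step from compound 1 to compound 2 is only a rough guide. A small rise in the number, or none beyond the scatter, is therefore expected. Compound 3 is estimated at 65 nM (range 25 nM to 220 nM), a step of a 1.7-fold higher number from compound 1 to compound 3 (0.23 log units; within the scatter).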

Compound 3, half-maximal effective concentration: 320 nM
Compound 3: middle estimate off by 4.9-fold (0.69 log units), on the low side, outside the stated range (above it).
By their numbers in this assay, from the lowest: compound 1; then compound 2; then compound 3.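

In this assay, methyl in place of hydrogen on a saturated chain carbon bound to an aromatic carbon and a saturated chain carbon, which turns 2-carboxyethyl into 1-(carboxymethyl)ethyl, gives an 8.4-fold higher number from compound 1 to compound 3 (0.93 log units; beyond the scatter). For the compounds shown here, the earlier step, a 3.4-fold higher number from compound 1 to compound 2 (0.53 log units; beyond the scatter), concerned only an aromatic carbon and said nothing about the chain, so this is the first sign that the chain position responds to this small change, with a number clearly beyond the scatter. No information is available on what lies behind this rise.

The compounds shown leave open whether fluorine or a hydroxyl group on the same chain carbon would raise the number as methyl does. They also leave open how an ethyl group there, or a longer chain carrying the carboxylic acid, would read in this assay.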